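Chloro in place of hydrogen: compound 3 to compound 4

A few compounds are considered here, and "the series" means these few. Any claim that something is new, unique, unknown or untested is made for them only; others in the source may bear on it.

Measured so far in a functional assay on U-87MG ATCC cells (Homo sapiens) for cytotoxicity, read by MTT assay, with a stated time of 48 h; on this read-out lower numbers stand for stronger inhibition and higher numbers for weaker inhibition:
- compound 1 `CC(=NNC(=S)Nc1ccccc1F)c1ccccn1`: 5 nM
- compound 2 `CC(=NNC(=S)Nc1cccc(I)c1)c1ccccn1`: 84 nM
- compound 3 `CC(=NNC(=S)Nc1ccccc1)c1ccccn1`: 1.4 nM
- compound 4 `CC(=NNC(=S)Nc1ccc(Cl)cc1)c1ccccn1`: not yet measured

Compound 3 holds the lowest of the three numbers, and both of the other compounds lie beyond the scatter from it. The next step gives compound 4, with chloro in place of hydrogen on an aromatic carbon, para to a large group: chloro in place of hydrogen on an aromatic carbon.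

Within the data shown here, two measured steps bear on this change, both removing a halogen from the aromatic ring. Replacing fluoro with hydrogen gave a modest step, a 3.6-fold lower number from compound 1 to compound 3 (0.55 log units; beyond the scatter). Replacing iodo with hydrogen gave a large one, a 60-fold lower number from compound 2 to compound 3 (1.78 log units; beyond the scatter). Neither compound 1 nor compound 2 carries its halogen at the place taken by chloro, so this reading is only an analogy. Adding a halogen to compound 3 has raised the number in both measured cases, so a rise is expected in this assay, of a size somewhere between those two steps.

The expected step is a 7.1-fold higher number from compound 3 to compound 4 (0.85 log units; beyond the scatter). For compound 4 the estimate is 10 nM, with an expected range from 2 nM to 60 nM.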

Compound 4, half-maximal inhibitory concentration: 1.7 nM
Compound 4: middle estimate off by 5.9-fold (0.77 log units), on the high side, outside the stated range (below it).
By their numbers in this assay, from the lowest: compounds 3 and 4 (each within the scatter of the next); then compound 1; then compound 2.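

In this assay, chloro on an aromatic carbon, para to a large group, leaves the read-out unchanged within the scatter, with a 1.2-fold higher number from compound 3 to compound 4 (0.08 log units; within the scatter) as the step. A halogen on the ring of compound 3 therefore does not always raise the number, unlike the steps of a 3.6-fold lower number from compound 1 to compound 3 (0.55 log units; beyond the scatter) and a 60-fold lower number from compound 2 to compound 3 (1.78 log units; beyond the scatter) read in reverse, although the fluoro and iodo of those compounds stand at other places on the ring. Nothing available explains why chloro is tolerated at this place.

The compounds shown leave open whether fluoro or iodo would be tolerated here as chloro is, and so whether the earlier rises belong to the halogen or to its place on the ring. They also leave open how an amine or a carboxylic acid at this place would compare with compound 3.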